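The source may report more compounds than this note shows. Statements on the series, on what has been measured and on what is new or still open speak of the compounds shown alone.

In a functional assay on NCI-H661 cells (Homo sapiens) for antiproliferative activity, read by MTT assay, with a stated time of 72 h (on this read-out higher numbers stand for weaker inhibition and lower numbers for stronger inhibition), compound 1 `Cc1ccc(-c2noc(CCCCCCC(=O)Nc3ccccc3N)n2)cc1` gives 410 nM and compound 2 `Nc1ccccc1NC(=O)CCCCCCc1nc(-c2ccc(Cl)cc2)no1` gives 11200 nM as the higher of the two numbers, which leaves compound 2 the weaker inhibitor of the pair. Next comes compound 3 `Nc1ccccc1NC(=O)CCCCCCc1nc(-c2ccc([N+](=O)[O-])cc2)no1` with nitro in place of chloro on an aromatic carbon, para to a large group (nitro in place of chloro on an aromatic carbon). For the measured compounds named here, only one measured step bears on it: a 27-fold higher number from compound 1 to compound 2 (1.44 log units; beyond the scatter) for chloro in place of methyl, a large step. Going by the values given here, it shows that swapping this group can move the number far in this assay but gives no direction for nitro, and no nitro compound has been measured. Among the compounds with values here, with compound 2 at 11200 nM as the top of the numbers so far, a moderate step to a lower number is expected. An estimated 3.7-fold lower number from compound 2 to compound 3 (0.57 log units; beyond the scatter) is carried forward here. For compound 3 the expected value is 3000 nM with a range from 600 nM to 15000 nM in this estimate.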

Compound 3, half-maximal inhibitory concentration: > 100000 nM
Compound 3: a limit, no number; the forecaster's own chance of this, stated with the estimate: 5%; middle value at least 33-fold (1.52 log units) away from the limit.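

Compound 3 reads only as a limit of the assay, not as a number: the limit of > 100000 nM in this assay, at which 1 of the 3 values shown sits.

The replacement of chloro by nitro gives an at least 8.9-fold higher number from compound 2 to compound 3 (0.95 log units; beyond the scatter), and the replacement of methyl by nitro gives an at least 240-fold higher number from compound 1 to compound 3 (2.38 log units; beyond the scatter). The earlier pair showed one large rise in the number on leaving methyl; the third compound shows that this position, para to a large group, can push the number further still, and compound 1 stays the strongest inhibitor of the three, with its steps to both others beyond the scatter.

As far as these compounds go, how far the true value of compound 3 lies past its limit stays open, so both new steps give only a minimum size. Also open, from the compounds shown here alone, is whether an amine or a methoxy group at this position, or a longer chain, would bring the number back towards that of compound 1.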